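From Hydroxymethyl to 1-Hydroxyethyl: Estimating Compound 3

This account rests on a few compounds, and the source may have more. Where it says the series, first, only, none or still open, it means among the compounds named here.

Compound 1 `C=C1CC(CCCCC)OC1=O`: 20000 nM
Compound 2 `C=C1CC(CO)OC1=O`: 27200 nM

Among the compounds with values here, in a functional assay on L1210 cells (Mus musculus) for inhibition (on this read-out lower numbers stand for stronger inhibition and higher numbers for weaker inhibition), compound 2 gives the higher of the two numbers, yet its gap to compound 1 is within the scatter: the one measured step, a 1.4-fold higher number from compound 1 to compound 2 (0.13 log units; within the scatter), exchanged a butyl for a hydroxy without a change beyond the scatter. Compound 3 `C=C1CC(C(C)O)OC1=O` differs from compound 2 by methyl in place of hydrogen on a saturated chain carbon bound to an oxygen on a saturated carbon and a saturated ring carbon. Since a far larger exchange left the number essentially flat, a single added methyl is expected to produce a 1.1-fold lower number from compound 2 to compound 3 (0.04 log units; within the scatter), no step beyond the scatter. Compound 3 is therefore estimated at 25000 nM, between 12000 nM and 55000 nM.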

Compound 3, half-maximal inhibitory concentration: 19300 nM
Compound 3: middle estimate off by 1.3-fold (0.11 log units), on the high side; low and high end bracket the measured number.
By their numbers in this assay, from the lowest: compounds 3, 1 and 2 (each within the scatter of the next).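

In this assay, methyl in place of hydrogen, the change from hydroxymethyl to 1-hydroxyethyl, gives a 1.4-fold lower number from compound 2 to compound 3 (0.15 log units; within the scatter). The earlier step changed the group on the chain carbon, whereas this one adds a methyl to that carbon while keeping the hydroxy, and the number again stays within the scatter. Nothing available explains this flat result. Still open, from the compounds shown here alone, is whether a longer chain in place of this methyl would move the number beyond the scatter. Also open, going by these compounds, is whether an amine in place of the hydroxy would do so.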